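This account rests on a few compounds, and the source may have more. Where it says the series, first, only, none or still open, it means among the compounds named here.

Measured in a functional assay on K562 cells (Homo sapiens) for antiproliferative activity, with a stated time of 72 h; on this read-out higher numbers stand for weaker inhibition and lower numbers for stronger inhibition:
compound 1 `OC[C@H]1O[C@@H](n2cnc3c(NCc4ccc(F)cc4)ncnc32)[C@H](O)[C@@H]1O` gives 2700 nM.
compound 2 `Cc1ccc(CNc2ncnc3c2ncn3[C@@H]2O[C@H](CO)[C@@H](O)[C@H]2O)cc1` reaches only the assay limit, > 166000 nM.
compound 3 `OC[C@H]1O[C@@H](n2cnc3c(NCc4ccc(Cl)c(Cl)c4)ncnc32)[C@H](O)[C@@H]1O` gives 10800 nM.

Compound 3 holds the higher of the two numbers; its nearest neighbour is compound 1, with a 4.0-fold higher number from compound 1 to compound 3 (0.60 log units; beyond the scatter). Compound 4 `OC[C@H]1O[C@@H](n2cnc3c(NCc4cccc(O)c4O)ncnc32)[C@H](O)[C@@H]1O` is not yet measured and differs from compound 3 in one place: 2,3-dihydroxyphenyl in place of 3,4-dichlorophenyl on a saturated chain carbon bound to a nitrogen on an aromatic ring. Going by the values given here, two steps bear on it, both swapping the same aryl group on the saturated chain carbon: a 4.0-fold higher number from compound 1 to compound 3 (0.60 log units; beyond the scatter) was modest, an at least 15-fold lower number from compound 2 to compound 3 (1.18 log units; beyond the scatter) was large. Neither of them involves hydroxy groups; the direction is therefore open, and swaps of this kind have moved this assay by modest to large amounts in both directions. Compound 4 is expected to sit near compound 3 or somewhat weaker, a 1.4-fold higher number from compound 3 to compound 4 (0.14 log units; within the scatter), estimated at 15000 nM with a range from 3000 nM to 80000 nM.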

Compound 4, half-maximal inhibitory concentration: 25800 nM
Compound 4: the middle estimate sits 1.7-fold (0.24 log units) below what was measured; the range from low to high includes it.
By their numbers in this assay, from the lowest: compound 1; then compound 3; then compound 4. At a limit, above all of these: compound 2.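

In this assay, 2,3-dihydroxyphenyl on the saturated chain carbon bound to a nitrogen on an aromatic ring brings hydrogen-bond donors to this position and retains measurable activity, yet it falls behind both halogenated aryl groups, with a 2.4-fold higher number from compound 3 to compound 4 (0.38 log units; beyond the scatter) and a 9.6-fold higher number from compound 1 to compound 4 (0.98 log units; beyond the scatter). Against 4-methylphenyl the same group gives an at least 6.4-fold lower number from compound 2 to compound 4 (0.80 log units; beyond the scatter). The value of compound 2 is a limit: the limit of > 166000 nM in this assay, at which 1 of the 4 values shown sits.

The compounds shown do not separate the hydroxy groups from where they sit on the ring. From the compounds shown here alone, how a single hydroxy, a methoxy or an amine on this aryl ring would read remains open.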